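The source may report more compounds than this note shows. Statements on the series, on what has been measured and on what is new or still open speak of the compounds shown alone.

Measured so far in a functional assay on the whole organism for inhibition, with Mus musculus as the target; on this read-out lower numbers stand for an effect already at smaller amounts and higher numbers for an effect only at larger amounts of compound:
Compound 1 (`CN1Cc2c(N)cccc2C(c2ccc(Cl)cc2)C1`) gives 1.1 mg/kg
Compound 2 (`CCCCNC(=O)Nc1cccc2c1CN(C)CC2c1ccccc1`) gives 23 mg/kg

Compound 2 stands highest of the two at 23 mg/kg while compound 1 sits clearly lower. Compound 3 (`CCCCNC(=O)Nc1cccc2c1CN(C)CC2c1ccc(Cl)cc1`) is compound 2 with one change (chloro in place of hydrogen on an aromatic carbon) namely chloro in place of hydrogen on an aromatic carbon. Among the measured compounds shown here, no measured pair shows this change alone. Compound 1 at 1.1 mg/kg also bears a 4-chlorophenyl group but differs elsewhere too, which makes it only a weak guide. A modest move to a lower number is expected in this assay (a 2.3-fold lower number from compound 2 to compound 3 (0.36 log units; beyond the scatter)). Compound 3 is estimated at 10 mg/kg (range 3 mg/kg to 35 mg/kg).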

Compound 3, dose for half-maximal effect: 15 mg/kg
Compound 3: middle estimate off by 1.5-fold (0.18 log units), on the low side, within the range that was stated.
By their numbers in this assay, from the lowest: compound 1; then compounds 3 and 2 (each within the scatter of the next).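

In this assay, the change from phenyl to 4-chlorophenyl gives a 1.5-fold lower number from compound 2 to compound 3 (0.19 log units; within the scatter), so with the butylcarbamoyl group present, the chloro has no effect that stands out from the scatter. Butylcarbamoyl in place of hydrogen on a nitrogen on an aromatic ring gives a 14-fold higher number from compound 1 to compound 3 (1.13 log units; beyond the scatter), a large step with the chloro present in both compounds. Nothing measured here explains either step.

Still open, going by these compounds, is whether a fluoro or a methoxy group at this place would behave like the chloro. On these data alone, it is also open whether a shorter chain such as methylcarbamoyl would keep the low number of compound 1.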